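A few compounds are considered here, and "the series" means these few. Any claim that something is new, unique, unknown or untested is made for them only; others in the source may bear on it.

Measured so far:
- Compound 1 `COc1ccc(-c2cncc3[nH]c(=O)n(Cc4cc(OC)c(OC)c(OC)c4)c23)cc1O`: > 20000 nM (a limit)
- Compound 2 `COc1ccc(-c2cc3c(cn2)[nH]c(=O)n3-c2cc(OC)c(OC)c(OC)c2)cc1`: 930 nM

In a functional assay on A2780 cells (Homo sapiens) for antiproliferative activity, read by MTT assay, with a stated time of 48 h (a higher number here means a weaker inhibitor, a lower number a stronger inhibitor), compound 1 gives > 20000 nM, which is a limit of the assay. Among the measured compounds shown here, compound 2, at 930 nM, holds the only actual number. Compound 3 `COc1ccc(-c2cc3c(cn2)[nH]c(=O)n3-c2cc(OC)c(OC)c(OC)c2)cc1F` has fluoro in place of hydrogen on an aromatic carbon, ortho to a methoxy group and meta to a large group: fluoro in place of hydrogen on an aromatic carbon. For the measured compounds named here, no measured step covers this change, so a small shift in this assay is expected, with no firm direction and probably none beyond the scatter. The expected change is a 1.3-fold lower number from compound 2 to compound 3 (0.12 log units; within the scatter). The estimated value for compound 3 is 700 nM, within an expected range of 200 nM to 2500 nM.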

Compound 3, half-maximal inhibitory concentration: 730 nM
Compound 3: middle estimate off by 1.0-fold (0.02 log units), on the low side; low and high end bracket the measured number.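

Fluoro on the carbon ortho to the methoxy group is accepted in this assay, with a 1.3-fold lower number from compound 2 to compound 3 (0.11 log units; within the scatter) as the whole of the change. Among the compounds shown here, this is the first change confined to one place, and it shows that this carbon of the 4-methoxyphenyl ring can carry fluoro without a shift beyond the scatter. Nothing at hand bears on why this step is so small.

As far as these compounds go, whether chloro, trifluoromethyl or an amine on this same carbon would behave like fluoro stays open. So does the effect of removing the methoxy group beside which fluoro sits in compound 3.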